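Furan regioisomers on a nucleoside series in HCT-116 cells

A few compounds are considered here, and "the series" means these few. Any claim that something is new, unique, unknown or untested is made for them only; others in the source may bear on it.

Four compounds share a ribose-bearing bicyclic core and differ in the furan attached to it and in the substituents of the six-membered ring. Compound 1 `O=c1[nH]cnc2c1c(-c1ccoc1)cn2[C@@H]1O[C@H](CO)[C@@H](O)[C@H]1O` carries a furan-3-yl; in a functional assay on HCT-116 cells (Homo sapiens), read by MTT assay, with a stated time of 72 h (on this read-out lower numbers stand for stronger inhibition and higher numbers for weaker inhibition), compound 1 gives 14800 nM. Compound 2 `O=c1[nH]cnc2c1c(-c1ccco1)cn2[C@@H]1O[C@H](CO)[C@@H](O)[C@H]1O` is its furan-2-yl counterpart. In this assay compound 2 reaches only the limit of the assay, > 20000 nM. The change from compound 1 to compound 2 is furan-2-yl in place of furan-3-yl on an aromatic carbon and it yields an at least 1.3-fold higher number from compound 1 to compound 2 (0.13 log units; that floor lies within the scatter).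

Compound 3 `COc1nc(N)nc2c1c(-c1ccoc1)cn2[C@@H]1O[C@H](CO)[C@@H](O)[C@H]1O` keeps the furan-3-yl on a core whose six-membered ring carries a methoxy and an amino group; the difference between the two cores is not broken down here. In this assay compound 3 again sits at the limit of the assay, > 20000 nM. Compound 4 `COc1nc(N)nc2c1c(-c1ccco1)cn2[C@@H]1O[C@H](CO)[C@@H](O)[C@H]1O` is not yet measured. It differs from compound 3 by furan-2-yl in place of furan-3-yl on an aromatic carbon, the same change as between compound 1 and compound 2, at the same place.

Across the compounds measured so far, the limit of > 20000 nM in this assay, at which 2 of the 3 values shown sit, describes where most values sit. Since compound 3 is already at that limit and the same change did not lower the number from compound 1 to compound 2, the expected step for compound 4 is a step that the limit leaves unreadable from compound 3 to compound 4. Compound 4 is therefore estimated at 30000 nM in this assay, with an expected range from 15000 nM to 90000 nM, and most likely reported only as a limit.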

Compound 4, half-maximal inhibitory concentration: > 20000 nM
Compound 4: a limit, no number; the forecaster's own chance of this, stated with the estimate: 85%; the middle value lies beyond the limit too.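

In this assay compound 4 gives > 20000 nM, which is a limit and not a number. Compound 3 also stands at a limit, so the step from compound 3 to compound 4, furan-2-yl in place of furan-3-yl, cannot be read. The compounds shown leave open where the actual values of compound 3 and compound 4 lie, and whether this change has any effect on their shared core.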